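The source may report more compounds than this note shows. Statements on the series, on what has been measured and on what is new or still open speak of the compounds shown alone.

Compound 1 `Cc1cc(Cl)c2c(c1O)C(=O)C=CC2=O` is the most potent of the three measured compounds. In a functional assay on DU-145 cells (Homo sapiens) for cytotoxicity, read by XTT assay, with a stated time of 24 h (a lower number here means a stronger inhibitor, a higher number a weaker inhibitor), compound 1 gives 9300 nM. Compound 2 `CC(=O)Oc1cc(OC(C)=O)c2c(OC(C)=O)cc(C)c(Cl)c2c1OC(C)=O` is built on a different core, and the difference between the two cores is not broken down here; in this assay compound 2 gives 59600 nM. Compound 3 `CC(=O)Oc1cc(OC(C)=O)c2c(OC(C)=O)cc(C)cc2c1OC(C)=O` keeps the core of compound 2 and in this assay compound 3 gives 64600 nM. Compound 3 differs from compound 2 in one place: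

hydrogen in place of chloro on an aromatic carbon

This change made a step of a 1.1-fold higher number from compound 2 to compound 3 (0.03 log units; within the scatter).

Compound 4 `Cc1ccc2c(c1O)C(=O)C=CC2=O` has not yet been measured. It differs from compound 1 in one place:

hydrogen in place of chloro on an aromatic carbon

Within the data shown here, this is the same kind of change as the one from compound 2 to compound 3, but its surroundings differ: in compound 1 the place is meta to a methyl group and para to a hydroxy group, whereas in compound 2 it is ortho to a methyl group and para to an acetoxy group. Because the step of a 1.1-fold higher number from compound 2 to compound 3 (0.03 log units; within the scatter) stayed within the scatter, the same kind of change on the core of compound 1 is expected to give a similarly small step, estimated at a 1.1-fold higher number from compound 1 to compound 4 (0.03 log units; within the scatter). In this assay compound 4 is therefore expected to give about 10000 nM, most likely between 4000 nM and 25000 nM.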

Compound 4, half-maximal inhibitory concentration: 15400 nM
Beside the measured number, compound 4's estimate is 1.5-fold (0.19 log units) below it, and the stated range covers the measured number.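

In this assay, hydrogen in place of chloro on the core of compound 1 gave a 1.7-fold higher number from compound 1 to compound 4 (0.22 log units; within the scatter), so this exchange moved the number no more than repeated measurements would be expected to. Set beside the earlier step, the result gives no sign that the two cores respond differently to this change: the same change on two cores in this assay, a 1.1-fold higher number (0.03 log units; within the scatter) from compound 2 to compound 3 and a 1.7-fold higher number (0.22 log units; within the scatter) from compound 1 to compound 4, 1.5-fold (0.18 log units) apart, within the scatter of two such steps This shows that, for these two pairs, the chloro could be exchanged for hydrogen on either core without a step beyond the scatter, but it rests on only two cores, with different neighbouring groups at the changed place, and does not show that the change would behave the same way on any further core, nor why the step is small.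

The compounds shown leave open whether a group other than hydrogen at the same place, such as an amine, a carboxylic acid or a longer alkyl chain, would produce a step beyond the scatter on either core. They also leave open which of the several structural differences between the core of compound 1 and the core of compound 2 accounts for the gap between their values, since those compounds differ in more than one place.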